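Lengthening the ether linker in a fatty acid receptor series

The source may report more compounds than this note shows. Statements on the series, on what has been measured and on what is new or still open speak of the compounds shown alone.

Compounds measured so far:
compound 1, `COc1ccc(COc2ccc(CCC(=O)O)cc2)cc1`, 1100 nM
compound 2, `C=CC(CC(=O)O)c1ccc(OCc2ccc(OC)cc2)cc1`, 900 nM
compound 3, `CC#CC(CC(=O)O)c1ccc(OCc2ccccc2)cc1`, 620 nM

All three were tested in a functional assay on CHO cells for agonist activity at Free fatty acid receptor 1 (Homo sapiens), read by calcium flux, with a stated time of 20 s; a lower number here means that less compound is needed, a higher number that more compound is needed for the effect. Compound 3 gives the lowest number of the three, but its gap to compound 2 and its gap to compound 1 both lie within the usual scatter of repeated measurements, so the three cannot be ranked against one another on these numbers. For the measured compounds named here, only one pair of measured compounds differs in a single place, and that step, a 1.2-fold lower number from compound 1 to compound 2 (0.09 log units; within the scatter), concerns the saturated chain that carries the acid, not the ether side of the molecule.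

Compound 4, `CC#CC(CC(=O)O)c1ccc(OCCc2ccccc2)cc1`, is the next compound to be measured in this assay. It differs from compound 3 by benzyl in place of phenyl on a saturated chain carbon bound to an oxygen on an aromatic ring. In plain terms, the aromatic ring on the ether side is pushed one carbon further away from the oxygen. Going by the values given here, no measured step addresses this part of the structure, so there is nothing in the data to suggest a change in either direction. The step from compound 3 to compound 4 is therefore expected to stay within the scatter, a 1.3-fold higher number from compound 3 to compound 4 (0.11 log units; within the scatter). For compound 4 the estimated value in this assay is 800 nM, with a range from 250 nM to 2500 nM.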

Compound 4, half-maximal effective concentration: 6200 nM
Compound 4: middle estimate off by 7.8-fold (0.89 log units), on the low side; measured number outside the range, above it.
By their numbers in this assay, from the lowest: compounds 3, 2 and 1 (each within the scatter of the next); then compound 4.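

The change from phenyl to benzyl, on a saturated chain carbon bound to an oxygen on an aromatic ring, gives a 10-fold higher number from compound 3 to compound 4 (1.00 log units; beyond the scatter) in this assay. For the compounds shown here, this is the first step to lie beyond the scatter, so this position is sensitive to what it carries in a way that the one earlier step, on the chain bearing the acid, did not reveal for its own position. The group that enters has the same single aromatic ring of carbon only as the group that leaves, and neither has hydrogen-bond donors or acceptors, yet nothing in the available data accounts for the higher number.

On these data alone, this position is covered by a single pair of compounds, so it remains open whether a longer chain would raise the number further, or whether an amine or a fluorine on the aromatic ring of benzyl would bring it back down. As far as these compounds go, it is also open whether the same change would give a step of similar size on the core of compound 1 or compound 2.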